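Replacing an Ethylcarbamoyl Group: Expected Oral Bioavailability

The source may report more compounds than this note shows. Statements on the series, on what has been measured and on what is new or still open speak of the compounds shown alone.

Compound 1 `CCCCCOC(=O)N1CCN(C(=O)[C@H](CCC(=O)O)NC(=O)c2cc(N3CCC(C(=O)NCC)CC3)nc(-c3ccccc3)n2)CC1` gives 8% in an in vivo ADME assay on the whole organism (strain Sprague-Dawley) for pharmacokinetics, with Rattus norvegicus as the target, at a dose of 5 mg/kg by the oral route; on this read-out higher numbers stand for higher oral bioavailability and lower numbers for lower oral bioavailability. Compound 2 `CCCCCOC(=O)N1CCN(C(=O)[C@H](CCC(=O)O)NC(=O)c2nc(-c3ccccc3)cc(N3CCC(COC)CC3)n2)CC1` gives 6% in this assay, and the two numbers lie within the scatter of each other, so compound 1 stands highest of the two only by a margin that means nothing. Compound 3 `CCCCCOC(=O)N1CCN(C(=O)[C@H](CCC(=O)O)NC(=O)c2cc(N3CCC(CNC)CC3)nc(-c3ccccc3)n2)CC1` differs from compound 1 in one place: (methylamino)methyl in place of ethylcarbamoyl on a saturated ring carbon. Among the compounds with values here, no measured pair shows a step of this kind, so no step beyond the scatter is expected in this assay. Compound 3 is expected to give 5% in this assay, between 1% and 15%. The expected step from compound 1 to compound 3 is a number 3 percentage points lower from compound 1 to compound 3 (within the scatter).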

Compound 3, oral bioavailability: 2%
Compound 3: the middle estimate sits 3 percentage points above what was measured, within the range that was stated.
By their numbers in this assay, from the lowest: compounds 3, 2 and 1 (each within the scatter of the next).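

At the saturated ring carbon of the 4-(ethylcarbamoyl)piperidin-1-yl group, this assay gives a number 6 percentage points lower from compound 1 to compound 3 (within the scatter) for (methylamino)methyl in place of ethylcarbamoyl. This first step measured at this position shows that the exchange, which removes the carbonyl and shortens the group from 5 heavy atoms to 3, cannot be told apart from the scatter. Nothing measured here bears on a cause for this result. The compounds shown leave open whether a carboxylic acid, a tertiary amine or a longer chain on this ring carbon would give a step beyond the scatter.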